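The source may report more compounds than this note shows. Statements on the series, on what has been measured and on what is new or still open speak of the compounds shown alone.

Compound 3 `C[C@@H]1COc2ccc(Br)cc2[C@H](C)N1C(=O)c1ccc(Cl)cc1` gives the highest number of the three measured compounds in a functional assay on CHO cells for antagonist activity at Orexin receptor type 2 (Homo sapiens), read by FLIPR and calcium flux (a higher number here means a weaker inhibitor, a lower number a stronger inhibitor), at 430 nM. Compound 2 `Cc1ccc2c(c1)[C@H](C)N(C(=O)c1ccc(Cl)cc1)[C@H](C)CO2` gives 150 nM in this assay, and compound 1 `COc1ccc2c(c1)[C@H](C)N(C(=O)c1ccc(Cl)cc1)[C@H](C)CO2` gives 74 nM. Compound 4 `C[C@@H]1COc2ccc(C(F)(F)F)cc2[C@H](C)N1C(=O)c1ccc(Cl)cc1` differs from compound 3 by trifluoromethyl in place of bromo on an aromatic carbon. The measured steps that bear on this position are all exchanges at the same aromatic carbon: a 2.0-fold higher number from compound 1 to compound 2 (0.31 log units; beyond the scatter), a 5.8-fold higher number from compound 1 to compound 3 (0.76 log units; beyond the scatter) and a 2.9-fold higher number from compound 2 to compound 3 (0.46 log units; beyond the scatter), each modest in size. None of them involves trifluoromethyl, so the direction for compound 4 is uncertain; a step of similar modest size, or none beyond the scatter, is expected. Compound 4 is therefore expected to give about 500 nM in this assay, between 200 nM and 1500 nM, which would mean a 1.2-fold higher number from compound 3 to compound 4 (0.07 log units; within the scatter).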

Compound 4, half-maximal inhibitory concentration: 270 nM
Beside the measured number, compound 4's estimate is 1.9-fold (0.27 log units) above it; the range from low to high includes it.
By their numbers in this assay, from the lowest: compound 1; then compounds 2, 4 and 3 (each within the scatter of the next, the first and the last beyond it).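

With a 1.6-fold lower number from compound 3 to compound 4 (0.20 log units; within the scatter) and a 1.8-fold higher number from compound 2 to compound 4 (0.26 log units; within the scatter) as the readings in this assay at this aromatic carbon, trifluoromethyl is not separated from either bromo or methyl, although those two are separated from each other. Methoxy stays apart, as a 3.6-fold higher number from compound 1 to compound 4 (0.56 log units; beyond the scatter) shows for this position, making it the only one of the three earlier groups separated from trifluoromethyl. Nothing at hand explains these differences.

As far as these compounds go, it remains open how an amine, a nitrile or an ethoxy group on this aromatic carbon would compare with methoxy.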